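Same Atoms, New Arrangement: The Step From Compound 1

This account rests on a few compounds, and the source may have more. Where it says the series, first, only, none or still open, it means among the compounds named here.

Measured so far in a physicochemical assay for solubility, at pH 7.4; a lower number here means a less soluble compound, a higher number a more soluble compound:
compound 1 `CNC1(C)CN(c2cc3c(cc2F)c(=O)c(C(=O)O)cn3C2CC2)C1`: 0.7 ug/mL
compound 2 `C[C@@H]1[C@@H](N(C)C)CN1c1c(F)cc2c(=O)c(C(=O)O)cn(C3CC3)c2c1F`: 97.1 ug/mL
compound 3 `C[C@H]1[C@H](N)CN1c1c(F)c(N)c2c(=O)c(C(=O)O)cn(C3CC3)c2c1F`: 37.7 ug/mL

Compound 1, at 0.7 ug/mL, gives the lowest of the three numbers, and both other compounds lie beyond the usual scatter from it. Compound 4 `C[C@H]1N(c2cc3c(cc2F)c(=O)c(C(=O)O)cn3C2CC2)C[C@]1(C)N` has the same atoms as compound 1, joined differently: a group of 7 heavy atoms (5 carbon, 2 nitrogen; one four-membered non-aromatic ring with 1 hetero atom) in place of a group of 7 heavy atoms (5 carbon, 2 nitrogen; one four-membered non-aromatic ring with 1 hetero atom), on an aromatic carbon. The swapped group sits on an aromatic carbon, ortho to a fluoro group.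

Within the data shown here, no measured pair shows a change of this kind. Compound 2 and compound 3 differ from compound 1 in more than one place, so their higher numbers offer only a loose guide to this assay. A small rise is expected, well short of the gap to compound 3, which gives 37.7 ug/mL, and it could stay within the scatter. The expected step is a 4.3-fold higher number from compound 1 to compound 4 (0.63 log units; beyond the scatter). The estimate for compound 4 is 3 ug/mL, with an expected range of 0.7 ug/mL to 15 ug/mL.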

Compound 4, solubility: 1.3 ug/mL
The estimate for compound 4 lay 2.3-fold (0.36 log units) above the measured number; the range from low to high includes it.
By their numbers in this assay, from the lowest: compounds 1 and 4 (each within the scatter of the next); then compound 3; then compound 2.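

Among these compounds, this is the first pair in the set that differs in one place, and it isolates a change on the aromatic carbon ortho to a fluoro group. Moving the same atoms around the four-membered ring gives, in this assay, a 1.9-fold higher number from compound 1 to compound 4 (0.27 log units; within the scatter), so this rearrangement, which brings in 2 defined stereocentres and keeps the donor and acceptor counts, does not separate the two compounds in this read-out. No measurement at hand explains how the two numbers relate.

Still open, on these data alone, is whether other spatial arrangements of those 2 stereocentres would give a number within the scatter of compound 4 as well. Also open, as far as these compounds go, is whether a different group on this carbon, such as piperazin-1-yl, would produce a step beyond the scatter from compound 1.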